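The source may report more compounds than this note shows. Statements on the series, on what has been measured and on what is new or still open speak of the compounds shown alone.

Of the compounds shown here, three with a shared core have been tested in a functional assay on the whole organism with Rattus norvegicus as the target, at a dose of 100 mg/kg; on this read-out higher numbers stand for more inhibition at the one dose given (going by the name of the read-out) and lower numbers for less inhibition. Compound 1 `C/N=C(\S)NCCCCn1nc(C)ccc1=O` carries a methyl on the core and a thiourea at the end of its chain; in this assay compound 1 gives 44.5%. Compound 2 `C/N=C(/NC#N)NCCCCn1nc(N2CCN(C)CC2)ccc1=O` and compound 3 `C/N=C(/NC#N)NCCCCn1nc(-c2ccc(Cl)cc2)ccc1=O` both carry a cyanoguanidine at the end of the chain and differ only on the aromatic carbon of the core. In this assay compound 2 gives 7.9%, whereas compound 3 gives 51%. Among the compounds with values here, compound 3 thus sits at the upper end of the three numbers, although compound 1 lies within the usual scatter of it; the one step that is known, a number 43.1 percentage points higher from compound 2 to compound 3 (beyond the scatter), is the only large movement in the set.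

Compound 4 `C/N=C(/NC#N)NCCCCn1nc(C)ccc1=O` keeps the cyanoguanidine of compound 3 but differs in one place: methyl in place of 4-chlorophenyl on an aromatic carbon. Within the data shown here, no measured step exchanges a 4-chlorophenyl for a methyl, so the large step from compound 2 to compound 3 bears only indirectly on it. Compound 1, which also carries a methyl on the core, gives a number close to that of compound 3, which argues against a large drop. Compound 4 is therefore expected to give 40%, within a range of 15% to 62%, an estimated step of a number 11 percentage points lower from compound 3 to compound 4 (beyond the scatter).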

Compound 4, a percentage reported as inhibition, in the whole organism at one dose (the size of the read-out at that dose, not a potency): 23.5%
For compound 4 the middle estimate is 16.5 percentage points above the measured one, within the range that was stated.
By their numbers in this assay, from the lowest: compound 2; then compound 4; then compounds 1 and 3 (each within the scatter of the next).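

In this assay, three cyanoguanidine compounds can now be compared at the same aromatic carbon of the core, and methyl falls between the other two groups: replacing 4-chlorophenyl with methyl gives a number 27.5 percentage points lower from compound 3 to compound 4 (beyond the scatter), while replacing 4-methylpiperazin-1-yl with methyl gives a number 15.6 percentage points higher from compound 2 to compound 4 (beyond the scatter). With methyl held constant on the core, the group at the end of the chain also matters, as the change from thiourea to cyanoguanidine gives a number 21 percentage points lower from compound 1 to compound 4 (beyond the scatter), so the closeness of compound 1 and compound 3 said little about methyl itself. No measured evidence here explains either change.

The compounds shown leave open whether the higher number with 4-chlorophenyl depends on the aromatic ring or on its chlorine, a question that a plain phenyl at this carbon would help to separate. They also leave open whether the change from thiourea to cyanoguanidine would give a similar step with 4-chlorophenyl on the core rather than methyl.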